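Dropping the hydroxyl at the benzylic side chain

A few compounds are considered here, and "the series" means these few. Any claim that something is new, unique, unknown or untested is made for them only; others in the source may bear on it.

Compound 1, `CCCCC[C@@H](O)/C=C/C=C/c1ccccc1/C=C/[C@@H](O)[C@@H](O)CCCC(=O)OC`: 17.3%
Compound 2, `CCCCC[C@@H](O)/C=C/c1ccccc1/C=C/[C@@H](O)[C@@H](O)CCCC(=O)OC`: 32.2%
Compound 3, `CCCCCC(O)c1ccccc1/C=C/[C@@H](O)[C@@H](O)CCCC(=O)OC`: 22.3%

In a functional assay on the whole organism (strain FVB) for inhibition, with Mus musculus as the target, at a dose of 15 ug/kg by the intravenous route (on this read-out lower numbers stand for less inhibition and higher numbers for more inhibition at the one dose given (going by the name of the read-out)), compound 3 gives 22.3%. Going by the values given here, its number lies within the scatter of both compound 1 and compound 2, so the three cannot be placed in an order from these data alone; only the step of a number 14.9 percentage points higher from compound 1 to compound 2 (beyond the scatter) is beyond the scatter, while the step of a number 9.9 percentage points lower from compound 2 to compound 3 (within the scatter) is not.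

Compound 4, `CCCCCC/C=C/c1ccccc1/C=C/[C@@H](O)[C@@H](O)CCCC(=O)OC`, is obtained from compound 3 by the change (a group of 8 heavy atoms (8 carbon; no ring) in place of a group of 7 heavy atoms (6 carbon, 1 oxygen; no ring), on an aromatic carbon). Both measured steps exchange a group of 9 heavy atoms for a group of 7 heavy atoms, each keeping one oxygen, and neither matches the present change in which a 1-hydroxyhexyl leaves and a chain of 8 carbon with one double bond outside aromatic rings enters. Among the compounds with values here, no measured step therefore speaks directly to it, and the two measured steps point in opposite directions. A step of no great size is expected in this assay for compound 4, namely a number 2.3 percentage points lower from compound 3 to compound 4 (within the scatter). Compound 4 is estimated to give 20%, between 5% and 38%.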

Compound 4, a percentage reported as inhibition, in the whole organism at one dose (the size of the read-out at that dose, not a potency): 23.9%
Compound 4: middle estimate off by 3.9 percentage points, on the low side; the range from low to high includes it.
By their numbers in this assay, from the lowest: compounds 1, 3, 4 and 2 (each within the scatter of the next, the first and the last beyond it).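

In this assay, the step of a number 1.6 percentage points higher from compound 3 to compound 4 (within the scatter) shows that the 1-hydroxyhexyl on this aromatic carbon can give way to a chain with no hydrogen-bond donor or acceptor and one double bond outside aromatic rings without moving the number beyond the scatter. The hydroxy on the side chain is likewise not shown to matter, since removing it gives a number 8.3 percentage points lower from compound 2 to compound 4 (within the scatter), and the step of a number 6.6 percentage points higher from compound 1 to compound 4 (within the scatter) also stays within the scatter, even though compound 1 and compound 2 lie beyond the scatter of each other. No measurement here offers an explanation for these numbers.

Going by these compounds, whether an amine or a carboxylic acid on this side chain would shift the number beyond the scatter remains open. So does the outcome for a longer chain on the same aromatic carbon.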